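This account rests on a few compounds, and the source may have more. Where it says the series, first, only, none or still open, it means among the compounds named here.

In a functional assay on LNCaP cells (Homo sapiens) for antiproliferative activity (on this read-out higher numbers stand for weaker inhibition and lower numbers for stronger inhibition), compound 3 `CCC[C@@H]1C[C@@H](c2ccc(Cl)c(Cl)c2)[C@H](NC(=O)c2cc(-c3c(Cl)cnn3C)c(Cl)o2)CN1` offers no number to start from, its result being "not determined" (no result reported). Compound 4 `Cn1ncc(Cl)c1-c1cc(C(=O)N[C@@H]2CN[C@H](CC(=O)NC3CC3)C[C@H]2c2ccc(Cl)c(Cl)c2)oc1Cl` differs from it by cyclopropylcarbamoyl in place of ethyl on a saturated chain carbon bound to a saturated ring carbon. Going by the values given here, no measured step covers this exact change. The closest evidence comes from two compounds that carry other groups at that place, compound 1 `Cn1ncc(Cl)c1-c1cc(C(=O)N[C@@H]2CN[C@H](CCN3CCC(O)CC3)C[C@H]2c2ccc(Cl)c(Cl)c2)oc1Cl` with 1140 nM and compound 2 `Cn1ncc(Cl)c1-c1cc(C(=O)N[C@@H]2CN[C@H](CC(=O)O)C[C@H]2c2ccc(Cl)c(Cl)c2)oc1Cl` with 640 nM. The step between them, a 1.8-fold lower number from compound 1 to compound 2 (0.25 log units; within the scatter), stays within the scatter. Among the compounds with values here, no step from compound 3 can therefore be expected in size or direction, and compound 4 is expected to fall in the same region as these two values. For compound 4 the estimated value is 800 nM, with an expected range from 300 nM to 2200 nM.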

Compound 4, half-maximal inhibitory concentration: 190 nM
Compound 4: the middle estimate sits 4.2-fold (0.62 log units) above what was measured, and the stated range ends above it.
By their numbers in this assay, from the lowest: compound 4; then compounds 2 and 1 (each within the scatter of the next).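

In this assay, cyclopropylamino on the carbonyl carbon gives a 3.4-fold lower number from compound 2 to compound 4 (0.53 log units; beyond the scatter) and the full cyclopropylcarbamoyl group gives a 6.0-fold lower number from compound 1 to compound 4 (0.78 log units; beyond the scatter), so this position, where compound 1 and compound 2 stayed within the scatter, now shows steps beyond it. Compound 4 thus has the lowest number of the three compounds with values. No measurement shown here explains this gain. As far as these compounds go, whether the amide hydrogen or the three-membered ring carries the step remains open, as a dimethylamino or cyclopentylamino group on that carbonyl carbon would test. From the compounds shown here alone, how a plain primary amide would compare also stays open.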